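The source may report more compounds than this note shows. Statements on the series, on what has been measured and on what is new or still open speak of the compounds shown alone.

In a functional assay on DU-145 cells (Homo sapiens) for inhibition, read by trypan blue exclusion, with a stated time of 96 h (on this read-out higher numbers stand for weaker inhibition of growth and lower numbers for stronger inhibition of growth), compound 1 `CSc1ccc(/C=C(\C(=O)c2ccc(Br)cc2)S(=O)(=O)Cc2ccc(F)cc2)cc1` gives 50000 nM as its value, the higher of the two actual numbers in this small set. In this assay compound 3 `CSc1ccc(/C=C(\C(=O)c2ccc(Br)cc2)S(=O)(=O)Cc2ccc(C)cc2)cc1` gives 10000 nM as its value, and the two differ by methyl in place of fluoro on an aromatic carbon (a 5.0-fold lower number from compound 1 to compound 3 (0.70 log units; beyond the scatter)). In this assay compound 2 `COc1cc(OC)c(/C=C(\C(=O)c2ccc(Cl)cc2)S(=O)(=O)c2ccc(Br)cc2)c(OC)c1` reads > 100000 nM and this is a limit of the assay, not a number.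

Compound 4 `CN(C)c1ccc(/C=C(\C(=O)c2ccc(Br)cc2)S(=O)(=O)Cc2ccc(F)cc2)cc1` keeps the core of compound 1 but carries dimethylamino in place of methylsulfanyl on an aromatic carbon, para to a large group (dimethylamino in place of methylsulfanyl on an aromatic carbon). Among the measured compounds shown here, no measured step touches the methylsulfanyl group. For the measured compounds named here, the one single change on record, the modest step at the fluoro group (a 5.0-fold lower number from compound 1 to compound 3 (0.70 log units; beyond the scatter)), therefore bears only indirectly, as a guide to how far one substitution can move the numbers here. A step of about that size or smaller is expected, with the direction uncertain and leaning toward a lower number, since compound 1 (50000 nM) already stands at the high end. The estimated change is small to modest (a 2.0-fold lower number from compound 1 to compound 4 (0.30 log units; within the scatter)). For compound 4 the expected value is 25000 nM within an estimated range of 5000 nM to 100000 nM in this read-out.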

Compound 4, concentration for 50% growth inhibition: 50000 nM
For compound 4 the middle estimate is 2.0-fold (0.30 log units) below the measured one, within the range that was stated.
By their numbers in this assay, from the lowest: compound 3; then compounds 1 and 4 (each within the scatter of the next). At a limit, above all of these: compound 2.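

Among the compounds shown here, until this result, the only single change on record in this assay lay at the fluoro group, and the position para to a large group had no step of its own. Here that position gets its first reading, no change at the digits printed from compound 1 to compound 4 (within the scatter), so going from 4-(methylsulfanyl)phenyl to 4-(dimethylamino)phenyl, a change from a sulfur-linked to a nitrogen-linked group, leaves the number where it stood, whereas the one change at the fluoro group gave a 5.0-fold lower number from compound 1 to compound 3 (0.70 log units; beyond the scatter). This is a single pair, so it describes this exchange on the core of compound 1 and no wider pattern, and nothing on record speaks to why the number holds.

From the compounds shown here alone, what a hydroxyl, a carboxylic acid or a longer chain at this position would do remains open. Also open is whether the step seen with methyl in place of fluoro would carry over to the dimethylamino series of compound 4, since the compounds shown hold no such pair.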